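Purine glycinamide series: working notes on compound 3 to compound 4

A few compounds are considered here, and "the series" means these few. Any claim that something is new, unique, unknown or untested is made for them only; others in the source may bear on it.

Compound 1, `O=C(CN(c1nc(Cl)nc2[nH]cnc12)C1CC1)NCC(=O)OCc1ccccc1`: 18.7%
Compound 2, `NCCCC[C@H](NC(=O)CN(c1nc(Cl)nc2[nH]cnc12)C1CC1)C(=O)OCc1ccccc1`: 26.1%
Compound 3, `O=C(O)CC[C@H](NC(=O)CN(c1nc(Cl)nc2[nH]cnc12)C1CC1)C(=O)O`: 26.8%

All three numbers come from a functional assay on the whole organism (Tail, strain ICR) with Mus musculus as the target, in the tail flick test, with a stated time of 30 min, at a dose of 25 umol/kg by the oral route; on this read-out higher numbers stand for a stronger effect at the one dose given and lower numbers for a weaker effect. Among the three, the number for compound 3 is the largest shown, yet its gaps to compound 2 and to compound 1 both fall within the scatter, so the three compounds cannot be told apart on these data.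

Compound 4, `CSCC[C@H](NC(=O)CN(c1nc(Cl)nc2[nH]cnc12)C1CC1)C(=O)O`, differs from compound 3 in one place: methylsulfanyl in place of carboxy on a saturated chain carbon, three bonds along the chain from an amide-type nitrogen and a carbonyl carbon. Within the data shown here, the only measured step in the set, a number 7.4 percentage points higher from compound 1 to compound 2 (within the scatter), concerns a different change at a different position and bears on the present one only in showing that a sizeable alteration of the side chain left the read-out within the scatter. Among the measured compounds shown here, no measured pair exchanges carboxy for methylsulfanyl, so nothing here points to a shift in either direction beyond the scatter.

Compound 4 is therefore expected to read about 25% in this assay, with a range from 10% to 40%. The expected step from compound 3, a number 1.8 percentage points lower from compound 3 to compound 4 (within the scatter), is estimated to lie within the scatter.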

Compound 4, a percentage reported as activity, at one dose (the size of the read-out at that dose, not a potency): 20.4%
Compound 4: middle estimate off by 4.6 percentage points, on the high side, and the stated range covers the measured number.
By their numbers in this assay, from the lowest: compounds 1, 4, 2 and 3 (each within the scatter of the next).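

Among these compounds, at this position, on a saturated chain carbon, three bonds along the chain from an amide-type nitrogen and a carbonyl carbon, replacing carboxy with methylsulfanyl in this assay gives a number 6.4 percentage points lower from compound 3 to compound 4 (within the scatter) as the first measured pair for this change. The side chain can therefore end in either group, one with a hydrogen-bond donor and one without, and the read-out stays within the scatter, which the earlier step could not show because it concerned a different change at a different position. No measurement at hand accounts for this result at the position.

The compounds shown leave open whether a hydroxyl group, a phenyl ring or a longer chain ending in methylsulfanyl at this same chain carbon would move the read-out beyond the scatter, since the two groups compared here span only part of what the position could carry. With a single oral dose and a single stated time, they also leave open whether compound 3 and compound 4 would still read alike at other doses or times.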